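Halogen swap on the shared core: cytotoxicity working notes

The source may report more compounds than this note shows. Statements on the series, on what has been measured and on what is new or still open speak of the compounds shown alone.

Compound 1 `CN1CCC(NC(=O)c2ccc(Nc3ncc([N+](=O)[O-])c(NC4CCCC4)n3)cc2)CC1`: 5800 nM
Compound 2 `CN1CCC(NC(=O)c2ccc(Nc3ncc(Br)c(NC4CCCC4)n3)cc2)CC1`: 2400 nM

Compound 2 gives the lowest of the two numbers in a functional assay on HepG2 cells (Homo sapiens) for cytotoxicity, read by MTT assay, with a stated time of 48 h; a lower number here means a stronger inhibitor, a higher number a weaker inhibitor; its nearest neighbour is compound 1, which lies beyond the scatter above it. Going by the values given here, the only measured step, a 2.4-fold lower number from compound 1 to compound 2 (0.38 log units; beyond the scatter), replaced nitro with bromo at the same aromatic carbon. Compound 3 `CN1CCC(NC(=O)c2ccc(Nc3ncc(F)c(NC4CCCC4)n3)cc2)CC1` carries fluoro in place of bromo on an aromatic carbon. Among the compounds with values here, no measured step exchanges one halogen for another, so that step is the only partial guide; a halogen-to-halogen swap is expected to stay within the scatter, with the estimated step of a 1.3-fold higher number from compound 2 to compound 3 (0.10 log units; within the scatter). For compound 3 the estimate in this assay is 3000 nM, expected between 1200 nM and 8000 nM.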

Compound 3, half-maximal inhibitory concentration: 10000 nM
Compound 3: the middle estimate sits 3.3-fold (0.52 log units) below what was measured; the whole stated range lies below it.
By their numbers in this assay, from the lowest: compound 2; then compounds 1 and 3 (each within the scatter of the next).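

The choice of halogen counts on this aromatic carbon in this assay, with a 4.2-fold higher number from compound 2 to compound 3 (0.62 log units; beyond the scatter), so bromo and fluoro are not interchangeable here. Fluoro and nitro do not separate, with a 1.7-fold higher number from compound 1 to compound 3 (0.24 log units; within the scatter), which leaves bromo as the only one of the three groups standing apart from the others. Nothing available accounts for the gap between the two halogens.

From the compounds shown here alone, whether chloro would track bromo or fluoro remains open. So does whether a nitrile or an amine at this carbon would keep the number of compound 2 or that of compound 3.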